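The source may hold more compounds than are shown below. What is called first, only, known or untested is meant among the compounds shown, and "the series" means these compounds.

Compound 3 `COC(=O)c1cc(-c2cccc(NC(=O)c3ccc(/C=C/C(=O)c4ccc(OC)cc4OC)cc3)c2)on1` was tested in an ADME assay on Vero cells (Chlorocebus sabaeus) for cytotoxicity, read by MTT assay, with a stated time of 72 h (on this read-out higher numbers stand for lower toxicity in this test and lower numbers for higher toxicity in this test), where its result, > 50 ug/mL, is a limit of the test rather than a number. Its relatives stand likewise. Compound 1 `COC(=O)c1cc(-c2cccc(NC(=O)c3ccc(C4OC4C(=O)c4ccc(Cl)cc4)cc3)c2)on1` gives > 20 ug/mL in this assay, which is a limit. Compound 2 `COC(=O)c1cc(-c2cccc(NC(=O)c3ccc(/C=C/C(=O)c4ccc(F)cc4)cc3)c2)on1` gives > 20 ug/mL in this assay, again a limit. The steps a step that the two limits leave unreadable from compound 1 to compound 2 and a step that the two limits leave unreadable from compound 2 to compound 3 therefore cannot be sized because two values sit at the limit of > 20 ug/mL in this assay, at which 2 of the 3 values shown sit, and one at the limit of > 50 ug/mL in this assay, at which 1 of the 3 values shown sits. Compound 4 `COC(=O)c1cc(-c2cccc(NC(=O)c3ccc(/C=C/C(=O)c4ccccc4Cl)cc3)c2)on1` differs from compound 3 by 2-chlorophenyl in place of 2,4-dimethoxyphenyl on a carbonyl carbon. Nothing among these results points to a change beyond the scatter, so the step of an at least 1.2-fold lower number from compound 3 to compound 4 (0.09 log units; that floor lies within the scatter) is expected to be small. For compound 4 the estimate is 40 ug/mL, within 15 ug/mL to 100 ug/mL, most likely reported once more as a limit.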

Compound 4, half-maximal cytotoxic concentration: > 25 ug/mL
Compound 4 ended at the assay's limit; the forecaster's own chance of this, stated with the estimate: 80%; the middle value lies beyond the limit too.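

Going by these compounds alone, compound 4, like compounds 1, 2 and 3, gives only a limit and not a number, and no step from any of them to compound 4 can be read. As far as these compounds go, what stays open is the concentration at which any of these four compounds becomes toxic to the cells.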